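Amides of a carboxylic acid in a rat paw edema model

The source may hold more compounds than are shown below. What is called first, only, known or untested is meant among the compounds shown, and "the series" means these compounds.

Compound 1 `COc1cc2c(cc1OC)C(CC(=O)O)CC2` is the free carboxylic acid of a small dimethoxy-substituted bicyclic core. Among the measured compounds shown here, in a functional assay on the whole organism (strain Wistar) for inhibition, with Rattus norvegicus as the target, read by paw edema, with a stated time of 6 h, at a dose of 100 mg/kg (a higher number here means more inhibition at the dose given (going by the name of the read-out), a lower number less inhibition), compound 1 gives 20.4%, the lower of the two numbers measured so far. For the measured compounds named here, its amide partner, compound 2 `COc1cc2c(cc1OC)C(CC(=O)Nc1ccc(Cl)cc1)CC2`, gives 61.1% in this assay, and the only measured step, a number 40.7 percentage points higher from compound 1 to compound 2 (beyond the scatter), shows that putting (4-chlorophenyl)amino in place of hydroxy on the carbonyl carbon raised inhibition well beyond the scatter.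

Compound 3 `COc1cc2c(cc1OC)C(CC(=O)Nc1ccccn1)CC2` is the next amide of compound 1. It differs from compound 1 as follows: (pyridin-2-yl)amino in place of hydroxy on a carbonyl carbon. Going by the values given here, no step to a (pyridin-2-yl)amino amide has been measured, so the only guide is the step to compound 2. Since that step was large and in the upward direction, a rise of similar kind is expected for compound 3, though the aromatic ring now carries a hetero atom, and so the size of the gain is less certain.

The expected step is a number 29.6 percentage points higher from compound 1 to compound 3 (beyond the scatter). Compound 3 is therefore estimated to give 50% in this assay, within a range from 30% to 70%.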

Compound 3, a percentage reported as inhibition, in the whole organism at one dose (the size of the read-out at that dose, not a potency): 29.6%
For compound 3 the middle estimate is 20.4 percentage points above the measured one; the measured number lies below the stated range.
By their numbers in this assay, from the lowest: compounds 1 and 3 (each within the scatter of the next); then compound 2.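

In this assay, (pyridin-2-yl)amino in place of hydroxy on the carbonyl carbon gives a number 9.2 percentage points higher from compound 1 to compound 3 (within the scatter), so forming an amide at this position does not by itself bring the gain that compound 2 showed. The group on the amide nitrogen matters here: pyridin-2-yl in place of 4-chlorophenyl gives a number 31.5 percentage points lower from compound 2 to compound 3 (beyond the scatter), and among these three compounds the clear rise over the acid belongs to compound 2 alone. Nothing available explains why these two amides part so widely in the paw edema read-out.

Pyridin-2-yl and 4-chlorophenyl differ in two ways at once, in the ring nitrogen and in the chlorine, so the compounds shown cannot say which of the two goes with the difference; a plain phenylamino amide or a (5-chloropyridin-2-yl)amino amide would separate them. They also leave open whether an amide with a saturated group on the nitrogen, such as cyclohexylamino, or a methyl ester in place of the acid would stay with compound 1 and compound 3 or move towards compound 2.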